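A Quinolinyl Sulfonamide Weighed for Cell Tolerance

This account rests on a few compounds, and the source may have more. Where it says the series, first, only, none or still open, it means among the compounds named here.

Compound 1 `O=C(Nc1ncc(C(Oc2ccc3cc(Br)ccc3c2)c2ccc(Cl)cc2)s1)c1cccs1`, compound 2 `COCCCNc1ncc(C(Oc2ccc3cc(Br)ccc3c2)c2ccc(Cl)cc2)s1` and compound 3 `O=S(=O)(Nc1ncc(C(Oc2ccc3cc(Br)ccc3c2)c2ccc(Cl)cc2)s1)c1ccccc1` share one core and differ in a single attached group. In an ADME assay on HepG2 2.2.15 cells (Homo sapiens) for cytotoxicity (a lower number here means that less compound is tolerated, a higher number that more compound is tolerated), compound 1 is reported as "not toxic" (no number reported), and compound 2 likewise as "not toxic" (no number reported), with no number behind either word. Compound 3 is the only one with a figure, and that figure is a limit of this assay rather than a measured value: > 50000 nM. It therefore stands at the limit of > 50000 nM in this assay, at which 1 of the 3 values shown sits, and all three compounds appear tolerated by the cells.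

Compound 4 `O=S(=O)(Nc1ncc(C(Oc2ccc3cc(Br)ccc3c2)c2ccc(Cl)cc2)s1)c1cccc2cccnc12` keeps the shared core and changes only the sulfonyl substituent: quinolin-8-yl in place of phenyl on a sulfonyl sulfur. Within the data shown here, no pair of measured compounds shows what such a swap does here, so no measured step guides the size of the change. Given that compound 3 sits at > 50000 nM, the step from compound 3 to compound 4 in this assay is expected to be no larger than the scatter, in either direction. Compound 4 is thus expected to give about 50000 nM, within 20000 nM to 120000 nM. The expected step is a number no higher from compound 3 to compound 4 (the limit leaves the size open), and a limit rather than a number is the likelier report.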

Compound 4, half-maximal cytotoxic concentration: > 50000 nM
Compound 4 ended at the assay's limit (the forecaster's own chance of this, stated with the estimate: 70%); the middle value lies on the limit itself.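

Compound 3 and compound 4 both end at a limit of this assay rather than at a number, so no step between them can be read: the limit of > 50000 nM in this assay, at which 2 of the 4 values shown sit.

The compounds shown leave open what concentration these cells fail to tolerate, and whether quinolin-8-yl in place of phenyl on a sulfonyl sulfur alters it.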